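Methoxy for Fluoro on the Aryl of Compound 2

A few compounds are considered here, and "the series" means these few. Any claim that something is new, unique, unknown or untested is made for them only; others in the source may bear on it.

Compound 2 `Cn1ccc2c(Oc3ccc(NC(=O)c4cn(-c5ccc(F)cc5)c5ccccc5c4=O)cc3F)ccnc21` gives 2010 nM in a functional assay on HepG2 cells (Homo sapiens) for inhibition, read by MTT assay, with a stated time of 72 h (on this read-out higher numbers stand for weaker inhibition and lower numbers for stronger inhibition), the higher of the two numbers in hand. Within the data shown here, compound 1 `O=C(Nc1ccc(Oc2ccnc3[nH]ccc23)cc1)c1cn(-c2ccc(Br)cc2)c2ccccc2c1=O` gives 220 nM in this assay, and that number lies beyond the scatter below the one for compound 2. Compound 3 `COc1ccc(-n2cc(C(=O)Nc3ccc(Oc4ccnc5c4ccn5C)c(F)c3)c(=O)c3ccccc32)cc1` differs from compound 2 by methoxy in place of fluoro on an aromatic carbon. Among the measured compounds shown here, no measured pair shows this change, so the step of a 1.1-fold lower number from compound 2 to compound 3 (0.05 log units; within the scatter) is expected to be small, in no settled direction, and within the scatter. Compound 3 is therefore expected to give 1800 nM, between 600 nM and 5500 nM.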

Compound 3, half-maximal inhibitory concentration: 3750 nM
Compound 3: middle estimate off by 2.1-fold (0.32 log units), on the low side, and the stated range covers the measured number.
By their numbers in this assay, from the lowest: compound 1; then compounds 2 and 3 (each within the scatter of the next).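

Among these compounds, the change from 4-fluorophenyl to 4-methoxyphenyl gives a 1.9-fold higher number from compound 2 to compound 3 (0.27 log units; within the scatter) in this assay, the first measured pair at this position. Fluoro and methoxy are thus not told apart here, and methoxy, with its added hydrogen-bond acceptor, brings no step beyond the scatter. No evidence accompanies this step to speak to its cause.

Compound 1 differs from both compounds in more than one place, so its bromo cannot be read against them. On these data alone, how an amine or a carboxylic acid would read at this position remains open.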